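Swapping a Pyrimidine for a Dioxo Ring on the Oxazole

A few compounds are considered here, and "the series" means these few. Any claim that something is new, unique, unknown or untested is made for them only; others in the source may bear on it.

Among the measured compounds shown here, compound 2 `O=C(CCCCCCc1ccccc1)c1ncc(-c2cncnc2)o1` is the stronger of the two compounds measured so far. For the measured compounds named here, in an assay (Rattus norvegicus) for inhibition of Fatty-acid amide hydrolase 1 (Homo sapiens) (a lower number here means a stronger inhibitor, a higher number a weaker inhibitor), compound 2 gives 22 nM, while compound 1 `O=C(CCCCCCc1ccccc1)c1ncc(-c2ccc(F)cc2)o1` gives 62 nM; the only step measured, a 2.8-fold lower number from compound 1 to compound 2 (0.45 log units; beyond the scatter), came from putting pyrimidin-5-yl in place of 4-fluorophenyl. Compound 3 `O=C(CCCCCCc1ccccc1)c1ncc(-c2cc(=O)[nH]c(=O)[nH]2)o1` has not yet been measured. It differs from compound 2 as follows: a group of 8 heavy atoms (4 carbon, 2 nitrogen, 2 oxygen; one six-membered aromatic ring with 2 hetero atoms) in place of a group of 6 heavy atoms (4 carbon, 2 nitrogen; one six-membered aromatic ring with 2 hetero atoms), on an aromatic carbon. Going by the values given here, the one measured step shows that trading the ring on this aromatic carbon for another six-membered aromatic ring with two hetero atoms can shift the number modestly, but it gives no guide to a ring that brings two hydrogen-bond donors and two double bonds outside aromatic rings. The expectation is therefore a modest step upward, a 2.7-fold higher number from compound 2 to compound 3 (0.44 log units; beyond the scatter), with wide uncertainty. Compound 3 is expected to give 60 nM, somewhere between 15 nM and 300 nM.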

Compound 3, inhibition constant: 12 nM
Estimate against measurement, compound 3: 5.0-fold (0.70 log units) above, and the stated range ends above it.
By their numbers in this assay, from the lowest: compounds 3 and 2 (each within the scatter of the next); then compound 1.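

In this assay, the step of a 1.8-fold lower number from compound 2 to compound 3 (0.26 log units; within the scatter) lies within the scatter, so this position, next to the ring oxygen, accepts a group of 8 heavy atoms with 2 hydrogen-bond donors without a clear change in the number. Set against the 4-fluorophenyl group, the same group gives a 5.2-fold lower number from compound 1 to compound 3 (0.71 log units; beyond the scatter) and lies beyond the scatter, so both rings with 2 hetero atoms shown here give lower numbers than the carbon-only ring. Nothing measured here tells what lies behind these numbers.

The compounds shown leave open whether the ring itself is needed at this position, since a carboxylic acid or an amine in its place could be compared directly. They also leave open whether the two ring hydrogens matter, which a version carrying methyl groups on the ring nitrogens would test.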